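Swapping a Methyl for a Methoxy on a Shared Core

The compounds below may be only part of what the source reports. "The series", "measured", "known", "first", "only" and "open" are said of these compounds alone.

Of the compounds shown here, two built on one core have been measured. Compound 1 `COc1ccc(C2C(C#N)=C(N)OC(c3c[nH]c4ccccc34)=C2C#N)cc1OC` carries a 3,4-dimethoxyphenyl group on a saturated ring carbon, and compound 2 `Cc1ccc(C2C(C#N)=C(N)OC(c3c[nH]c4ccccc34)=C2C#N)cc1` carries a 4-methylphenyl group in its place. In a functional assay, tested at 200 ug/mL (a higher number here means a stronger effect of the compound at the concentration tested, a lower number a weaker effect), compound 1 gives 26.1%, and compound 2 gives 6.2%. For the measured compounds named here, the single measured step, a number 19.9 percentage points lower from compound 1 to compound 2 (beyond the scatter), leaves compound 2 with the lower of the two numbers, set apart from compound 1 beyond the usual scatter.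

Compound 3 `COc1ccc(C2C(C#N)=C(N)OC(c3c[nH]c4ccccc34)=C2C#N)cc1` has not yet been measured. It differs from compound 2 in one place: methoxy in place of methyl on an aromatic carbon. The measured step bears on this change only in part: it replaced the 3,4-dimethoxyphenyl with the 4-methylphenyl, whereas compound 3 carries a 4-methoxyphenyl, midway between the two. Because a number 19.9 percentage points lower from compound 1 to compound 2 (beyond the scatter) was modest, a smaller rise is expected for compound 3, estimated as a number 8.8 percentage points higher from compound 2 to compound 3 (within the scatter). Compound 3 is therefore expected to give about 15% in this assay, within a range from 3% to 30%.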

Compound 3, a percentage reported as activity, at one concentration (the size of the read-out at that concentration, not a potency): 26.4%
Beside the measured number, compound 3's estimate is 11.4 percentage points below it; the measured number falls inside the stated range.
By their numbers in this assay, from the lowest: compound 2; then compounds 1 and 3 (each within the scatter of the next).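

Taken alone, the change from 4-methylphenyl to 4-methoxyphenyl moves the read-out in this assay: a number 20.2 percentage points higher from compound 2 to compound 3 (beyond the scatter), so the group on this aromatic carbon, para to a large group, matters by itself. The earlier step replaced the whole 3,4-dimethoxyphenyl group and could not show which part of it counted, but the second methoxy can now be judged separately: a number 0.3 percentage points higher from compound 1 to compound 3 (within the scatter), so compound 1 and compound 3 cannot be told apart, and among these compounds the second methoxy brings nothing measurable. Nothing available explains why methoxy and methyl differ here.

The compounds shown cover only methyl and methoxy at this place, so it remains open whether a hydroxyl group, a chlorine atom, an amine or a longer chain such as ethoxy would read like compound 2 or like compound 3. Also open, as far as these compounds go, is how a plain phenyl ring, with hydrogen at this place, would compare, and with it whether methoxy raises the number or methyl lowers it.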